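Toward compound 4: a tert-butoxycarbonyl on the aminomethyl

This account rests on a few compounds, and the source may have more. Where it says the series, first, only, none or still open, it means among the compounds named here.

Measured so far in a physicochemical assay for solubility; a lower number here means a less soluble compound, a higher number a more soluble compound:
compound 1 `NC(=O)c1ccccc1NC(=O)c1cc2cc([N+](=O)[O-])ccc2o1` gives 5 ug/mL;
compound 2 `O=C(Nc1ccccc1)c1cc2cc([N+](=O)[O-])ccc2o1` gives 25 ug/mL;
compound 3 `NCc1ccccc1NC(=O)c1cc2cc([N+](=O)[O-])ccc2o1` gives 5 ug/mL.

Compound 3 stands level with compound 1, the two together being the lowest of the three numbers, and compound 2 stands furthest from it, as the step of a 5.0-fold lower number from compound 2 to compound 3 (0.70 log units; beyond the scatter) shows. The step of no change at the digits printed from compound 1 to compound 3 (within the scatter) lies within the scatter.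

Compound 4 `CC(C)(C)OC(=O)NCc1ccccc1NC(=O)c1cc2cc([N+](=O)[O-])ccc2o1` differs from compound 3 in one place: tert-butoxycarbonyl in place of hydrogen on an amine nitrogen. Among the compounds with values here, no measured step adds a group of this kind to an amine nitrogen; the measured steps only exchange groups on an aromatic carbon of the shared core. Of these, a 5.0-fold lower number from compound 2 to compound 3 (0.70 log units; beyond the scatter) shows that adding the aminomethyl lowered this assay by a modest step, and no change at the digits printed from compound 1 to compound 3 (within the scatter) shows that exchanging the carbamoyl for the aminomethyl left it unchanged. The step from compound 3 to compound 4 is therefore expected to be small, either a modest lowering or none beyond the scatter, and the estimate for compound 4 is 3 ug/mL, between 1 ug/mL and 8 ug/mL, an expected step of a 1.7-fold lower number from compound 3 to compound 4 (0.22 log units; within the scatter).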

Compound 4, solubility: 25 ug/mL
The estimate for compound 4 lay 8.3-fold (0.92 log units) below the measured number, outside the stated range (above it).
By their numbers in this assay, from the lowest: compounds 1 and 3 (each within the scatter of the next); then compounds 2 and 4 (each within the scatter of the next).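

In this assay, this is the only step shown on an amine nitrogen rather than on an aromatic carbon of the shared core, and tert-butoxycarbonyl in place of hydrogen there gives a 5.0-fold higher number from compound 3 to compound 4 (0.70 log units; beyond the scatter), so this nitrogen is a place where the number can move. Within the data shown here, the aromatic carbon had so far given either a lower number or none beyond the scatter when it carried a substituent, yet ((tert-butoxycarbonyl)amino)methyl in place of hydrogen gives no change at the digits printed from compound 2 to compound 4 (within the scatter) and the same group in place of carbamoyl gives a 5.0-fold higher number from compound 1 to compound 4 (0.70 log units; beyond the scatter), so a substituent at this place need not bring the lower number seen with aminomethyl or carbamoyl. Nothing among the data given explains why the number responds in this way.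

The compounds shown leave open whether this step belongs to tert-butoxycarbonyl itself or would also come with a smaller group on the same amine nitrogen, such as an acetyl or a methyl. They also leave open how a carboxylic acid or a longer chain ending in an amine on that aromatic carbon would read in this assay.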